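Aryl amide exchange from compound 2 to compound 3

This account rests on a few compounds, and the source may have more. Where it says the series, first, only, none or still open, it means among the compounds named here.

Measured so far:
compound 1 `CN(C)c1ccc(C(=O)Nc2cccc(NC(=O)COc3ccc4c(c3)OCCO4)c2)cc1` — > 10000 nM
compound 2 `O=C(COc1ccc2c(=O)ccoc2c1)Nc1cccc(NC(=O)c2ccc(F)cc2)c1` — 129 nM

Among the compounds with values here, in an assay on isolated protein for inhibition of Rho-associated protein kinase 1 (Homo sapiens), read by scintillation counting, radiometric assay and 33P incorporation, with a stated time of 40 min, in the presence of a further agent that is not named here (a lower number here means a stronger inhibitor, a higher number a weaker inhibitor), compound 2 gives 129 nM, the only numbered value in this pair. For compound 1 this assay reports a limit only, > 10000 nM. Compound 1 thus stands at the limit of > 10000 nM in this assay, at which 1 of the 2 values shown sits. Within the data shown here, no step between two measured compounds is available, so nothing measured bears on the change now proposed.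

Compound 3 `O=C(COc1ccc2c(=O)ccoc2c1)Nc1cccc(NC(=O)c2cnc(C(F)(F)F)s2)c1` differs from compound 2 by 2-(trifluoromethyl)-1,3-thiazol-5-yl in place of 4-fluorophenyl on a carbonyl carbon. The exchange sits on a carbonyl carbon whose other neighbour is an amide-type nitrogen; the rest of compound 2 is kept.

Among the measured compounds shown here, with no measured step to lean on, the expectation for this assay is a step from compound 2 to compound 3 no larger than the usual scatter, with its direction left open. Compound 3 is estimated at 150 nM, with a range of 40 nM to 600 nM. The step this estimate means is a 1.2-fold higher number from compound 2 to compound 3 (0.07 log units; within the scatter), expected rather than measured.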

Compound 3, half-maximal inhibitory concentration: 160 nM
Compound 3: the middle estimate sits 1.1-fold (0.03 log units) below what was measured; measured number inside the range.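

In this assay, 2-(trifluoromethyl)-1,3-thiazol-5-yl in place of 4-fluorophenyl on the carbonyl carbon gives a 1.2-fold higher number from compound 2 to compound 3 (0.09 log units; within the scatter), so this position takes a five-membered aromatic ring with 2 hetero atoms as well as a six-membered aromatic ring of carbon only. The entering group carries 2 hydrogen-bond acceptors and the leaving group 0, and this difference comes with no step beyond the scatter. Nothing shown gives a reason for this outcome.

As far as these compounds go, whether the position also takes a saturated ring such as piperidine, or an aryl ring bearing an amine or a carboxylic acid, remains open. Compound 1 gives > 10000 nM, a limit of the assay, and it differs from compound 2 in more than one place, so that limit cannot be assigned to any single part.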